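A few compounds are considered here, and "the series" means these few. Any claim that something is new, unique, unknown or untested is made for them only; others in the source may bear on it.

Measured compounds in a functional assay on HeLa cells (Homo sapiens) for cytotoxicity, read by MTT assay, with a stated time of 72 h; a higher number here means a weaker inhibitor, a lower number a stronger inhibitor:
Compound 1, `COc1cc(/C=C/C(=O)c2ccccc2F)cc(OC)c1OC`, gives 228 nM
Compound 2, `COc1cc(OC)c(OC)cc1/C=C/C(=O)c1ccccc1F`, gives 293 nM
Compound 3, `COc1cc(/C=C/C(=O)c2ccccc2F)cc(OC)c1`, gives 62.9 nM

Compound 1 and compound 2 are built from the same atoms joined differently; the difference between the two cores is not broken down here. Their values in this assay lie within the scatter of each other. Compound 3 arises from compound 1 by hydrogen in place of methoxy on an aromatic carbon, and the step is a 3.6-fold lower number from compound 1 to compound 3 (0.56 log units; beyond the scatter).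

Compound 4, `COc1ccc(OC)c(/C=C/C(=O)c2ccccc2F)c1`, is not yet measured. It arises from compound 2 by hydrogen in place of methoxy on an aromatic carbon. This is the same kind of change, not the same: in compound 1 the carbon is ortho to two methoxy groups, whereas in compound 2 it is ortho to a methoxy group and meta to a methoxy group. Given a 3.6-fold lower number from compound 1 to compound 3 (0.56 log units; beyond the scatter), the step in this assay is expected to be a 2.4-fold lower number from compound 2 to compound 4 (0.39 log units; beyond the scatter), with added uncertainty from the differing surroundings. Compound 4 is therefore estimated at 120 nM, with a likely range from 40 nM to 350 nM.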

Compound 4, half-maximal inhibitory concentration: 96.1 nM
Compound 4: middle estimate off by 1.2-fold (0.10 log units), on the high side; the measured number falls inside the stated range.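

Hydrogen in place of methoxy on an aromatic carbon carries over between the two cores in this assay, where the new step is a 3.0-fold lower number from compound 2 to compound 4 (0.48 log units; beyond the scatter) and matches the earlier one in size: the same change on two cores in this assay, a 3.6-fold lower number (0.56 log units; beyond the scatter) from compound 1 to compound 3 and a 3.0-fold lower number (0.48 log units; beyond the scatter) from compound 2 to compound 4, 1.2-fold (0.08 log units) apart, within the scatter of two such steps

Neither pair goes against this, so the change can be read across these two cores as giving a lower number of like size. Among the compounds shown here, this rests on only two pairs in a single cell assay, and it shows neither that the step would hold on a further core nor why the number falls.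

Open, on these data alone, is whether a hydroxy group, an amine or a longer chain such as ethoxy on that aromatic carbon would give a step of similar size. Also open, as far as these compounds go, is whether the step survives when the fluorine on the other ring gives way to chlorine.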